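The compounds below may be only part of what the source reports. "The series", "measured", "known", "first", "only" and "open" are said of these compounds alone.

Among the compounds with values here, compound 2 `COCCCOc1nc(C(C)(C)C)ccc1CNC(=O)C(C)c1ccc(NS(C)(=O)=O)c(F)c1` carries the higher of the two numbers so far in an assay on cells for antagonist activity at transient receptor potential cation channel subfamily V member 1 (Homo sapiens), read by FLIPR and calcium flux, with a stated time of 6 min; a higher number here means a weaker inhibitor, a lower number a stronger inhibitor: compound 2 gives 5.6 nM, while compound 1 `CC(C(=O)NCc1ccc(C(C)(C)C)nc1N1CCCCCC1)c1ccc(NS(C)(=O)=O)c(F)c1` gives 0.9 nM. Within the data shown here, the only step that bears on the next change is a 6.2-fold higher number from compound 1 to compound 2 (0.79 log units; beyond the scatter). Compound 3 `CC(C(=O)NCc1ccc(C(C)(C)C)nc1SCCCN1CCCC1)c1ccc(NS(C)(=O)=O)c(F)c1` differs from compound 2 by (3-(pyrrolidin-1-yl)propyl)sulfanyl in place of 3-methoxypropoxy on an aromatic carbon. The entering group, like the azepan-1-yl of compound 1 at 0.9 nM, brings a non-aromatic nitrogen ring to this position, so a partial return toward the lower number is expected. For compound 3 the step is therefore expected as a 1.9-fold lower number from compound 2 to compound 3 (0.27 log units; within the scatter). Compound 3 is estimated at 3 nM, range 0.8 nM to 12 nM.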

Compound 3, inhibition constant: 17.1 nM
The estimate for compound 3 lay 5.7-fold (0.76 log units) below the measured number; measured number outside the range, above it.
By their numbers in this assay, from the lowest: compound 1; then compound 2; then compound 3.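

In this assay, a non-aromatic nitrogen ring at this position does not by itself keep the number low: the (3-(pyrrolidin-1-yl)propyl)sulfanyl group gives a 19-fold higher number from compound 1 to compound 3 (1.28 log units; beyond the scatter). It also falls short of the 3-methoxypropoxy group, with a 3.1-fold higher number from compound 2 to compound 3 (0.48 log units; beyond the scatter). Nothing available explains this rise.

From the compounds shown here alone, the step changes the linking atom and the chain end together, so the share of each remains open. A 3-(pyrrolidin-1-yl)propoxy group or a 3-methoxypropylsulfanyl group at this position would separate the two.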